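A few compounds are considered here, and "the series" means these few. Any claim that something is new, unique, unknown or untested is made for them only; others in the source may bear on it.

Compound 1 `C#Cc1cccc(Nc2ncnc3cc(NC(=O)/C=C/c4ccccc4)sc23)c1` is the weakest of the three compounds measured in a functional assay on HeLa cells (Homo sapiens) for antiproliferative activity, read by MTT assay, with a stated time of 48 h; a higher number here means a weaker inhibitor, a lower number a stronger inhibitor. There, compound 1 gives 20500 nM, while compound 3 `O=C(/C=C/c1ccccc1)Nc1cc2c(Nc3ccc(F)c(Cl)c3)ncnc2s1` gives 2140 nM and compound 2 `COc1ccc(/C=C/C(=O)Nc2cc3c(Nc4ccc(Cl)c(Cl)c4)ncnc3s2)cc1` gives 33 nM. Compound 4 `N#Cc1cccc(Nc2ncnc3cc(NC(=O)/C=C/c4ccccc4)sc23)c1` departs from compound 1 in one place, cyano in place of ethynyl on an aromatic carbon, meta to a large group. For the measured compounds named here, no two measured compounds differ in only one place, so the data offer no direct precedent for this change. The expected step of a 1.2-fold higher number from compound 1 to compound 4 (0.09 log units; within the scatter) is none beyond the scatter in this assay, and no clear direction is expected. The estimated value for compound 4 is 25000 nM, within an expected range from 8000 nM to 60000 nM.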

Compound 4, half-maximal inhibitory concentration: 7220 nM
Compound 4: middle estimate off by 3.5-fold (0.54 log units), on the high side; measured number below the stated range.
By their numbers in this assay, from the lowest: compound 2; then compound 3; then compound 4; then compound 1.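

In this assay, replacing ethynyl with cyano on this aromatic carbon gives a 2.8-fold lower number from compound 1 to compound 4 (0.45 log units; beyond the scatter). This first one-place comparison shows that the position, meta to a large group, responds to an exchange between two groups with the same heavy-atom count, of which only cyano adds a hydrogen-bond acceptor. Nothing measured here explains the change in potency. The compounds shown leave open whether an amine or a carboxylic acid on this carbon would move the number further, and whether cyano would give a similar step with other substituents on this ring.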